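A few compounds are considered here, and "the series" means these few. Any claim that something is new, unique, unknown or untested is made for them only; others in the source may bear on it.

Measured compounds in a functional assay on HeLa cells (Homo sapiens) for antiproliferative activity, read by MTT assay, with a stated time of 72 h; on this read-out lower numbers stand for stronger inhibition and higher numbers for weaker inhibition: compound 1 `O=C1O[C@H]([C@@H](O)Cn2cc(-c3cccc(O)c3)nn2)C(OCc2ccccc2)=C1OCc1ccccc1` gives 39300 nM; compound 3 `CCCCc1cn(C[C@H](O)[C@H]2OC(=O)C(OCc3ccccc3)=C2OCc2ccccc2)nn1` gives 18100 nM. Compound 2 `CCCCCc1ccc(-c2cn(C/C=C3\OC(=O)C(OCc4ccccc4)=C3OCc3ccccc3)nn2)cc1` reaches only a limit of the assay, > 100000 nM.

Compound 3 holds the lowest number of the two measured values; the step of a 2.2-fold lower number from compound 1 to compound 3 (0.34 log units; beyond the scatter) put it there, (the limit of > 100000 nM in this assay, at which 1 of the 3 values shown sits). Compound 4 `O=C1O[C@H]([C@@H](O)Cn2cc(CNS(=O)(=O)c3ccc(F)cc3)nn2)C(OCc2ccccc2)=C1OCc1ccccc1` differs from compound 3 by ((4-fluorophenyl)sulfonyl)amino in place of propyl on a saturated chain carbon bound to an aromatic carbon. Going by the values given here, only one measured step bears on this position, and it moved by a modest amount when an aromatic group was exchanged for a chain; the present change goes the other way, replacing a chain with a larger group. The step of a 1.7-fold higher number from compound 3 to compound 4 (0.22 log units; within the scatter) is therefore expected, toward a higher number, near or beyond the scatter. Compound 4 is estimated at 30000 nM, between 8000 nM and 100000 nM.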

Compound 4, half-maximal inhibitory concentration: 25000 nM
The estimate for compound 4 lay 1.2-fold (0.08 log units) above the measured number; measured number inside the range.
By their numbers in this assay, from the lowest: compounds 3, 4 and 1 (each within the scatter of the next, the first and the last beyond it). At a limit, above all of these: compound 2.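

In this assay the position takes a much larger group than butyl without a change that stands clear of the scatter (a 1.4-fold higher number from compound 3 to compound 4 (0.14 log units; within the scatter)). The (((4-fluorophenyl)sulfonyl)amino)methyl group also stays level with 3-hydroxyphenyl (a 1.6-fold lower number from compound 1 to compound 4 (0.20 log units; within the scatter)), so it does not separate from either group, although those two differ beyond the scatter. No measurement shown here explains this result.
Going by these compounds, whether an amine, a carboxylic acid or a longer chain at this position would stand apart from these values remains open. So does the part played by the fluorine, which a plain phenylsulfonyl group would address.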